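The compounds below may be only part of what the source reports. "The series", "measured", "known", "first", "only" and "open" are said of these compounds alone.

Compound 1 `COc1ccc(NC(=O)C2(C(=O)Nc3ccc(Nc4ncc5cc(C(=O)N(C)C)n(C6CCCC6)c5n4)cc3)CC2)cc1` gives 74.4% in a functional assay on A549 cells (Homo sapiens) for inhibition, read by CCK-8 assay, with a stated time of 72 h, tested at 1 uM (a lower number here means less inhibition of growth, a higher number more inhibition of growth at the concentration tested), the highest of the three numbers. Compound 2 `CN(C)C(=O)c1cc2cnc(Nc3ccc(NC(=O)C4(C(=O)Nc5cccc(C(F)(F)F)c5)CC4)cc3)nc2n1C1CCCC1` gives 15.7% and compound 3 `CN(C)C(=O)c1cc2cnc(Nc3ccc(NC(=O)C4(C(=O)Nc5ccc(C(F)(F)F)cc5)CC4)cc3)nc2n1C1CCCC1` gives -25.3%. The measured steps of a number 58.7 percentage points lower from compound 1 to compound 2 (beyond the scatter) and a number 99.7 percentage points lower from compound 1 to compound 3 (beyond the scatter) both exchange the methoxy for trifluoromethyl, and a number 41 percentage points lower from compound 2 to compound 3 (beyond the scatter) only moves that trifluoromethyl; none removes just the methyl of the methoxy. Compound 4 `CN(C)C(=O)c1cc2cnc(Nc3ccc(NC(=O)C4(C(=O)Nc5ccc(O)cc5)CC4)cc3)nc2n1C1CCCC1` differs from compound 1 by hydrogen in place of methyl on an oxygen on an aromatic ring. Among the measured compounds shown here, no measured step bears directly on this change, and the hydroxy keeps the oxygen on the aromatic ring that trifluoromethyl does not, so a smaller loss than the one from compound 1 to compound 3 is expected. For compound 4 this means an expected step of a number 24.4 percentage points lower from compound 1 to compound 4 (beyond the scatter). Compound 4 is estimated at 50%, range 10% to 85%.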

Compound 4, percent growth inhibition at one concentration: 93.6%
Compound 4: the middle estimate sits 43.6 percentage points below what was measured; measured number above the stated range.
By their numbers in this assay, from the lowest: compound 3; then compound 2; then compound 1; then compound 4.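

In this assay, hydrogen in place of methyl on the oxygen costs nothing, and the result is instead a number 19.2 percentage points higher from compound 1 to compound 4 (beyond the scatter), so an oxygen-bearing group here does not need its methyl. Compound 4 also sits well above both trifluoromethyl compounds, with a number 118.9 percentage points higher from compound 3 to compound 4 (beyond the scatter) and a number 77.9 percentage points higher from compound 2 to compound 4 (beyond the scatter), the latter step also changing where the group sits. No measurement at hand accounts for this order. Still open, as far as these compounds go, is whether an amine or a carboxylic acid in place of the hydroxy holds this level of inhibition, and how a longer chain on the oxygen, such as ethoxy, compares.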